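Acyl aryl variation in the sulfonamide anilide series

The source may hold more compounds than are shown below. What is called first, only, known or untested is meant among the compounds shown, and "the series" means these compounds.

Of the compounds shown here, two of the shared core have been measured in a functional assay on HEK293 cells for agonist activity at probable G-protein coupled receptor 27 (Homo sapiens), read by a luciferase reporter and beta-arrestin recruitment, with a stated time of 10 min; a higher number here means a larger maximal response, a lower number a smaller maximal response. Compound 1 `O=C(Nc1ccc(S(=O)(=O)Nc2ccccc2)cc1)c1ccc(Br)cc1F` gives 67% in this assay. Compound 2 `O=C(Nc1ccc(S(=O)(=O)Nc2ccccc2)cc1)c1ccc(Cl)cc1Cl` gives 100% in this assay. Going by the values given here, the one step between them, a number 33 percentage points higher from compound 1 to compound 2 (beyond the scatter), shows that the group on the carbonyl carbon alone can move the maximal response by a large amount. Compound 2 therefore stands highest of the two numbers; its nearest neighbour, compound 1, lies lower by that step, beyond the scatter.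

Compound 3 `O=C(Nc1ccc(S(=O)(=O)Nc2ccccc2)cc1)c1ccc(Cl)nc1F` is not yet measured. It differs from compound 2 in one place: 6-chloro-2-fluoropyridin-3-yl in place of 2,4-dichlorophenyl on a carbonyl carbon. Among the compounds with values here, no measured pair bears directly on this change; the only step, the one from compound 1 to compound 2, concerns a different exchange at the same carbonyl carbon, but it is large and points to this position as sensitive. Any direction is uncertain; a decrease from the top value of compound 2 is expected as the more likely case, with a wide range. For compound 3 the expected step is a number 30 percentage points lower from compound 2 to compound 3 (beyond the scatter), and the estimate is 70% with a range from 40% to 100%.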

Compound 3, largest response reached (Emax), in percent of the reference or control that the assay uses: 78%
Compound 3: the middle estimate sits 8 percentage points below what was measured, and the stated range covers the measured number.
By their numbers in this assay, from the lowest: compound 1; then compound 3; then compound 2.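

Working notes on the acyl aryl position: a ring with a hetero atom is compatible with a substantial response in this assay, although the exchange on the carbonyl carbon gives a number 22 percentage points lower from compound 2 to compound 3 (beyond the scatter). The same group also gives a number 11 percentage points higher from compound 1 to compound 3 (beyond the scatter), which places it between the two phenyl groups and shows that this position supports intermediate values as well as the two values seen earlier. Among these three compounds, the two acyl groups carrying fluorine both lie beyond the scatter below the 2,4-dichlorophenyl group, with no compound going against this, though the pattern rests on only two exchanges and no measured information on the origin of these differences is available here.

The exchange from compound 2 to compound 3 alters the ring nitrogen and the halogen set together, so the compounds shown do not separate the contribution of each; a 4-chloro-2-fluorophenyl group on the carbonyl carbon would bear directly on that question. Also open, going by these compounds, is how the response behaves with a non-halogen substituent on the acyl ring, such as an amine or a carboxylic acid.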